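Moving the Fluorine Around the Ring

The source may hold more compounds than are shown below. What is called first, only, known or untested is meant among the compounds shown, and "the series" means these compounds.

Three compounds sharing one core differ in a single aromatic group. In a functional assay on MCF7 cells (Homo sapiens) for inhibition, read by MTT assay, with a stated time of 48 h (on this read-out higher numbers stand for weaker inhibition and lower numbers for stronger inhibition), compound 1 `O=C(CSc1nnc(-c2ccncc2)n1-c1ccccc1)N/N=C/c1ccc([N+](=O)[O-])cc1` gives 15300 nM, compound 2 `O=C(CSc1nnc(-c2ccncc2)n1-c1ccccc1)N/N=C/c1ccc(Br)cc1` gives 7040 nM, and compound 3 `O=C(CSc1nnc(-c2ccncc2)n1-c1ccccc1)N/N=C/c1ccc(F)cc1` gives 12300 nM. Compound 3 thus sits second highest of the three numbers, within the scatter of both others. The steps measured so far are a 2.2-fold lower number from compound 1 to compound 2 (0.34 log units; beyond the scatter), a 1.2-fold lower number from compound 1 to compound 3 (0.09 log units; within the scatter) and a 1.7-fold higher number from compound 2 to compound 3 (0.24 log units; within the scatter); each replaces one group with another on an aromatic carbon. Compound 4 `O=C(CSc1nnc(-c2ccncc2)n1-c1ccccc1)N/N=C/c1cccc(F)c1` keeps the fluorine but shifts it: 3-fluorophenyl in place of 4-fluorophenyl on a carbon with a double bond to nitrogen. Going by the values given here, no measured step tests such a shift, and the group swaps themselves were small, so no change beyond the scatter is expected. Compound 4 is therefore estimated at 12000 nM, with a range from 5000 nM to 30000 nM. The expected step is a 1.0-fold lower number from compound 3 to compound 4 (0.01 log units; within the scatter).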

Compound 4, half-maximal inhibitory concentration: > 50000 nM
Compound 4: only a limit was reported; the forecaster's own chance of this, stated with the estimate: 5%; at least 4.1-fold (0.61 log units) between middle value and limit.
By their numbers in this assay, from the lowest: compounds 2, 3 and 1 (each within the scatter of the next, the first and the last beyond it). At a limit, above all of these: compound 4.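

With the same atoms joined differently, this assay shows an at least 4.0-fold higher number from compound 3 to compound 4 (0.60 log units; beyond the scatter), so where the fluorine sits on this phenyl ring matters, something compounds 1, 2 and 3 could not show. The gaps to the other two compounds are also beyond the scatter: an at least 7.1-fold higher number from compound 2 to compound 4 (0.85 log units; beyond the scatter) and an at least 3.2-fold higher number from compound 1 to compound 4 (0.51 log units; beyond the scatter). For compound 4 the reading is a limit, not a number: the limit of > 50000 nM in this assay, at which 1 of the 4 values shown sits.

Still open, from the compounds shown here alone, is whether a bromo or nitro group shifted in the same way would behave like the fluorine. Also open, going by these compounds, is what an amine or a carboxylic acid on this ring would give.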